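This account rests on a few compounds, and the source may have more. Where it says the series, first, only, none or still open, it means among the compounds named here.

Compounds measured so far in an ADME assay on HeLa cells (Homo sapiens) for inhibition, read by MTT assay, with a stated time of 48 h; on this read-out higher numbers stand for weaker inhibition and lower numbers for stronger inhibition:

compound 1 `CCOC(=O)C(=O)CC(=O)/C=C/c1cn(CCC(C)C)c2ccccc12`: "not determined" (no result reported)
compound 2 `CCOC(=O)C(=O)CC(=O)/C=C/c1cn(-c2ccc(O)cc2)c2ccccc12`: "not determined" (no result reported)
compound 3 `CC(C)CCn1cc(/C=C/C(=O)CC(=O)C(=O)O)c2ccccc21`: > 80000 nM

Only compound 3 has a reported result, since no result exists for compound 1 or compound 2. Compound 3 stands at > 80000 nM, which is a limit of the assay and not a number. It therefore gives a boundary rather than an exact starting point.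

Compound 4 `O=C(/C=C/c1cn(CC(=O)N2CCOCC2)c2ccccc12)CC(=O)C(=O)O` has not yet been measured. It differs from compound 3 by one change, ((morpholin-4-yl)carbonyl in place of isobutyl on a saturated chain carbon bound to an aromatic nitrogen), namely (morpholin-4-yl)carbonyl in place of isobutyl on a saturated chain carbon bound to an aromatic nitrogen. The rest of the structure is unchanged.

Within the data shown here, no step between measured compounds is available as a guide, so the expectation rests on compound 3 alone, with its limit of > 80000 nM as the only reference. The step expected in this assay is a step that the limit leaves unreadable from compound 3 to compound 4, which stays within the scatter and has no firm direction. For compound 4 the estimated value is 100000 nM, with an expected range of 40000 nM to 250000 nM.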

Compound 4, half-maximal inhibitory concentration: > 40000 nM
Compound 4 was reported as a limit; the forecaster's own chance of this, stated with the estimate: 75%; the middle value does not contradict the limit.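

In this assay compound 3 gives > 80000 nM, which is a limit. Compound 4 gives > 40000 nM, also a limit. Among these compounds, no step from compound 3 to compound 4 can be read. The compounds shown leave open whether either compound inhibits at any measurable concentration in this assay.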